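The compounds below may be only part of what the source reports. "The series", "measured", "known", "first", "only" and "open" are said of these compounds alone.

Measured compounds in the series:

- compound 1 `CC1=NN(C(=O)c2ccc([N+](=O)[O-])cc2)C(c2ccccc2O)C1` gives 36600 nM in a functional assay on PC-3 cells (Homo sapiens) for cytotoxicity, read by MTT assay, with a stated time of 48 h; on this read-out higher numbers stand for weaker inhibition and lower numbers for stronger inhibition
- compound 2 `CC1=NN(C(=O)COc2ccc(Cl)cc2)C(c2ccccc2O)C1` gives 38800 nM in this assay
- compound 3 `CC1=NN(C(=O)CCl)C(c2cc(Br)ccc2O)C1` gives 8890 nM in this assay

Compound 3 stands at the lowest number of the three. Compound 1 is the nearest, and its number is higher by more than the scatter; compound 2 is the furthest, also higher by more than the scatter. Among the measured compounds shown here, no pair among the measured compounds differs in a single place, so no measured single step exists to set a scale for what follows.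

Compound 4 `CCC(=O)N1N=C(C)CC1c1cc(Br)ccc1O` is not yet measured. It differs from compound 3 in one place: methyl in place of chloro on a saturated chain carbon bound to a carbonyl carbon. The shared core with its bromo-substituted hydroxyphenyl is kept; only the group on the carbonyl chain is exchanged.

Without a measured single step of any kind in this set, the direction of the change is open. The expectation is that compound 4 moves toward the weaker end of the range set by compound 1 and compound 2, with the step from compound 3 to compound 4 expected to be a 2.8-fold higher number from compound 3 to compound 4 (0.45 log units; beyond the scatter). Compound 4 is estimated at 25000 nM in this assay, expected to lie between 8000 nM and 80000 nM.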

Compound 4, half-maximal inhibitory concentration: 37800 nM
The estimate for compound 4 lay 1.5-fold (0.18 log units) below the measured number; the range from low to high includes it.
By their numbers in this assay, from the lowest: compound 3; then compounds 1, 4 and 2 (each within the scatter of the next).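

In this assay, among the compounds shown here, the exchange of chloro for methyl on a saturated chain carbon bound to a carbonyl carbon gives a 4.3-fold higher number from compound 3 to compound 4 (0.63 log units; beyond the scatter), and this is the first measured single step. It shows that this position is not silent: a change of one heavy atom for one heavy atom, with the rest of the structure kept, moves the number beyond the scatter, and the lower number belongs to the chloro member of the pair. The same difference can also be read as chloromethyl to ethyl, but no information at hand accounts for the size or direction of this step.

On these data alone, with only methyl and chloro compared on this carbon, it remains open whether the lower number is specific to chloro or would also appear with another group here, such as a fluoro, a bromo, a hydroxyl or an amine. As far as these compounds go, it is also open whether the same exchange would give a similar step on a core without the bromo group, or with a longer chain on the carbonyl.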